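The source may report more compounds than this note shows. Statements on the series, on what has been measured and on what is new or still open speak of the compounds shown alone.

In a functional assay on MKN-45 cells (Homo sapiens) for inhibition, read by CCK-8 assay, with a stated time of 24 h (on this read-out lower numbers stand for stronger inhibition and higher numbers for weaker inhibition), compound 1 `Cc1ccccc1-n1cc(-c2ccc(/C=C3\C(=O)Nc4ccccc43)cc2)nn1` gives 9770 nM and compound 2 `O=C1Nc2ccccc2/C1=C/c1ccc(-c2cn(-c3ccc(F)cc3)nn2)cc1` gives 16700 nM on the same read-out. Compound 2 stands within the scatter of compound 1, so these two compounds cannot be ranked. The next structure is compound 3 `N#Cc1cccc(-n2cc(-c3ccc(/C=C4\C(=O)Nc5ccccc54)cc3)nn2)c1`, which changes the same place again: 3-cyanophenyl in place of 4-fluorophenyl on an aromatic nitrogen with 3-cyanophenyl in place of 4-fluorophenyl on an aromatic nitrogen. Among the measured compounds shown here, one measured step bears on this change, the swap of 2-methylphenyl for 4-fluorophenyl at that nitrogen. For the measured compounds named here, no measured compound carries the nitrile, so the data give no direct guide to this group. Going by the values given here, with a 1.7-fold higher number from compound 1 to compound 2 (0.23 log units; within the scatter) as the sole precedent, a step beyond the scatter is not expected in this assay and neither direction is favoured. The estimate therefore amounts to a 1.4-fold lower number from compound 2 to compound 3 (0.14 log units; within the scatter) and is expected to be no real change. The expected value for compound 3 is 12000 nM within an estimated range of 4000 nM to 35000 nM on this read-out.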

Compound 3, half-maximal inhibitory concentration: > 20000 nM
Compound 3: only a limit was reported (the forecaster's own chance of this, stated with the estimate: 10%); middle value at least 1.6-fold (0.22 log units) away from the limit.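

In this assay compound 3 is reported only as a limit of the assay and not as a number: the limit of > 20000 nM in this assay, at which 1 of the 3 values shown sits.

Among the compounds shown here, replacing 2-methylphenyl with 3-cyanophenyl on the aromatic nitrogen gives an at least 2.0-fold higher number from compound 1 to compound 3 (0.31 log units; beyond the scatter), the first step at this position that clears the scatter, so the aryl group on this nitrogen can shift the read-out. Replacing 4-fluorophenyl with the same 3-cyanophenyl gives an at least 1.1-fold higher number from compound 2 to compound 3 (0.07 log units; that floor lies within the scatter), so the nitrile-bearing compound cannot be ranked against the fluorine-bearing one, and only the comparison with the 2-methylphenyl group gives a direction.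

From the compounds shown here alone, the true value of compound 3 remains unknown, which leaves both steps with a floor and no measured size. Also open, going by these compounds, is whether an amine or a carboxylic acid on this phenyl ring, or a plain alkyl chain in place of the aryl group on the nitrogen, would give a lower number than compound 1 at 9770 nM.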